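This account rests on a few compounds, and the source may have more. Where it says the series, first, only, none or still open, it means among the compounds named here.

Working notes on the series. Compound 1 `CCOC(=O)C12C(=O)OCC=C1COC2c1ccc(C(C)(C)C)cc1` and compound 2 `CCOC(=O)C12C(=O)OCC=C1COC2c1ccc(OC)cc1` share one core and differ only in the group on the aromatic ring. In a functional assay on HeLa cells (Homo sapiens) for cytotoxicity, read by MTT assay (on this read-out lower numbers stand for stronger inhibition and higher numbers for weaker inhibition), compound 1 gives 25400 nM and compound 2 gives 18300 nM; the two numbers lie within the scatter of each other, as a 1.4-fold lower number from compound 1 to compound 2 (0.14 log units; within the scatter) shows, so compound 2 stands beside compound 1 rather than apart from it. Compound 3 `CCOC(=O)C12C(=O)OCC=C1COC2c1ccc(N(C)C)cc1` carries dimethylamino in place of methoxy on an aromatic carbon. Among the measured compounds shown here, the only measured step that bears on this change is the swap of groups on the same aromatic carbon between those two compounds, which stayed within the scatter, so no step beyond the scatter is expected in this assay here either. Compound 3 is therefore estimated at 15000 nM, range 5000 nM to 45000 nM, an expected step of a 1.2-fold lower number from compound 2 to compound 3 (0.09 log units; within the scatter).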

Compound 3, half-maximal inhibitory concentration: 23400 nM
The estimate for compound 3 lay 1.6-fold (0.19 log units) below the measured number, and the stated range covers the measured number.
By their numbers in this assay, from the lowest: compounds 2, 3 and 1 (each within the scatter of the next).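

Dimethylamino on this aromatic carbon stays within the scatter of both neighbours in this assay (a 1.3-fold higher number from compound 2 to compound 3 (0.11 log units; within the scatter)) and (a 1.1-fold lower number from compound 1 to compound 3 (0.04 log units; within the scatter)). With three different groups now read at this place, none stands apart from the others, so the series gives no order among them. Nothing available points to a cause for this flat result.

As far as these compounds go, whether a carboxylic acid or a primary amine on this aromatic carbon would give a step beyond the scatter stays open. So does whether any change to the shared core would do so.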